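The source may hold more compounds than are shown below. What is called first, only, known or untested is meant among the compounds shown, and "the series" means these compounds.

Measured in a functional assay on cells (Cancer cell lines, Homo sapiens) for cytotoxicity, read by sulforhodamine B assay, with a stated time of 48 h; on this read-out lower numbers stand for stronger inhibition of growth and higher numbers for weaker inhibition of growth:

compound 1 `COc1ccc(C2=NN(C3=NC(=O)/C(=C4\C(=O)Nc5ccc(Br)cc54)S3)C(c3ccc(OC)cc3)C2)cc1`: 710 nM
compound 2 `COc1ccc(C2=NN(C3=NC(=O)/C(=C4\C(=O)Nc5ccc(Cl)cc54)S3)C(c3ccc(OC)cc3)C2)cc1`: 710 nM
compound 3 `CN(C)c1ccc(C2CC(c3ccccc3)=NN2C2=NC(=O)/C(=C3\C(=O)Nc4ccc(Br)cc43)S2)cc1`: 720 nM

Compound 1 and compound 2 share a core and differ by chloro in place of bromo on an aromatic carbon; the step on this assay is no change at the digits printed from compound 1 to compound 2 (within the scatter). Compound 3 carries a different core; the difference between the two cores is not broken down here. Its value and those of compound 1 and compound 2 all lie within the scatter of one another, so no order among the three is claimed.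

Compound 4 `CN(C)c1ccc(C2CC(c3ccccc3)=NN2C2=NC(=O)/C(=C3\C(=O)Nc4ccc(Cl)cc43)S2)cc1` is not yet measured. It differs from compound 3 by chloro in place of bromo on an aromatic carbon, the same change already seen between compound 1 and compound 2, at the same place. The step of no change at the digits printed from compound 3 to compound 4 (within the scatter) is therefore expected to stay within the scatter, because no change at the digits printed from compound 1 to compound 2 (within the scatter). For compound 4 the expected value is 720 nM, with a likely range from 450 nM to 1150 nM.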

Compound 4, concentration for total growth inhibition: 690 nM
The estimate for compound 4 lay 1.0-fold (0.02 log units) above the measured number; measured number inside the range.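

In this assay, chloro in place of bromo on an aromatic carbon gives a 1.0-fold lower number from compound 3 to compound 4 (0.02 log units; within the scatter), and the change carries from one core to the other without a gap beyond the scatter: the same change on two cores in this assay, no change at the digits printed (within the scatter) from compound 1 to compound 2 and a 1.0-fold lower number (0.02 log units; within the scatter) from compound 3 to compound 4, 1.0-fold (0.02 log units) apart, within the scatter of two such steps

On these two pairs, the exchange of these two halogens leaves the growth-inhibition read-out within the scatter on both cores. This does not show that the step would hold on other cores, or that any other change at this place would carry across in the same way.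

Still open, on these data alone, is whether a group other than bromo or chloro at this place, such as an amine, a carboxylic acid or a nitrile, would shift the value on either core. As far as these compounds go, it is equally open whether such a shift would match between the two cores.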